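A Chloro Step Carried From One Core to Another

This account rests on a few compounds, and the source may have more. Where it says the series, first, only, none or still open, it means among the compounds named here.

Compound 1 `CCc1cccc(NC(=O)CN2CCN(c3ccccn3)CC2)c1` and compound 2 `Cc1cccc(NC(=O)CN2CCC(c3ccccc3)CC2)c1` are both anilides joined to a basic ring, but the difference between the two cores is not broken down here. In an assay on cells for antagonist activity at D(4) dopamine receptor (Homo sapiens), read by luminescence and beta-arrestin recruitment, with a stated time of 90 min (on this read-out higher numbers stand for weaker inhibition and lower numbers for stronger inhibition), compound 1 gives 370 nM, while compound 2 gives 135 nM. Compound 3 `CCc1cccc(NC(=O)CN2CCN(c3ccc(Cl)cn3)CC2)c1` carries chloro in place of hydrogen on an aromatic carbon, and in this assay compound 3 gives 10400 nM, which means a 28-fold higher number from compound 1 to compound 3 (1.45 log units; beyond the scatter).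

Compound 4 `Cc1cccc(NC(=O)CN2CCC(c3ccc(Cl)cc3)CC2)c1` has not been measured yet. It differs from compound 2 by chloro in place of hydrogen on an aromatic carbon. This is the same kind of change as that between compound 1 and compound 3, not the same one: there the chloro enters on a six-membered aromatic ring with 1 nitrogen, two atoms from the ring nitrogen, whereas here it enters on a six-membered aromatic ring of carbon only. Because a 28-fold higher number from compound 1 to compound 3 (1.45 log units; beyond the scatter) pointed toward weaker inhibition, a shift in the same direction is expected for compound 4, though the changed surroundings leave its size uncertain. The estimated step in this assay is a 5.2-fold higher number from compound 2 to compound 4 (0.71 log units; beyond the scatter). Compound 4 is therefore expected to give 700 nM in this assay, within 200 nM to 3000 nM.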

Compound 4, half-maximal inhibitory concentration: 42400 nM
Estimate against measurement, compound 4: 61-fold (1.78 log units) below, outside the stated range (above it).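

On the core of compound 2, the chloro step in this assay reads as a 310-fold higher number from compound 2 to compound 4 (2.50 log units; beyond the scatter). Both chloro steps point toward weaker inhibition, but their sizes do not match: the same change on two cores in this assay, a 28-fold higher number (1.45 log units; beyond the scatter) from compound 1 to compound 3 and a 310-fold higher number (2.50 log units; beyond the scatter) from compound 2 to compound 4, 11-fold (1.05 log units) apart, beyond the scatter of two such steps. The direction carried across these two cores and the size did not, yet two pairs give no rule for other cores, and they cannot separate the effect of the core from that of the ring taking the chloro, which is carbon only in the phenyl to 4-chlorophenyl change and holds a nitrogen in the other pair.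

The compounds shown leave open whether fluoro or methoxy in the place of the chloro would shift the number as far on either core. Also open, from the compounds shown here alone, is whether the step on the core of compound 2 would read the same with the ethyl of compound 1 in place of its methyl.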